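The source may hold more compounds than are shown below. What is called first, only, known or untested is meant among the compounds shown, and "the series" means these compounds.

Working notes on the series. Compound 3 `CNC(=O)[C@H]1C[C@@H]2CNC[C@@H](C2)C1` carries a methylamino amide on the shared core; in an assay on CHO cells for displacement of a labelled ligand from Neuronal acetylcholine receptor; alpha3/beta4 (Homo sapiens), read by scintillation counting, with a stated time of 2 h (on this read-out lower numbers stand for stronger inhibition and higher numbers for weaker inhibition), compound 3 gives "not determined" (no result reported), so no single number places it. The series as measured so far rests on compound 1 `O=C(C1CC1)[C@H]1C[C@@H]2CNC[C@@H](C2)C1`, which in this assay gives 4100 nM. Compound 2 `O=C(c1ccco1)[C@H]1C[C@@H]2CNC[C@@H](C2)C1`, the furanyl ketone, in this assay gives "not determined" (no result reported) and adds no anchor either. Compound 4 `CCCNC(=O)[C@H]1C[C@@H]2CNC[C@@H](C2)C1` is still to be measured. The change from compound 3 to compound 4 is ethyl in place of hydrogen on a saturated chain carbon bound to an amide-type nitrogen. Within the data shown here, no step between measured compounds is available, so the size of this step in this assay cannot be gauged from the series; the expectation is that compound 4 does not move far from the region set by compound 1, in either direction, within the scatter or modestly beyond it. Compound 4 is therefore expected in this assay at about 5000 nM, with a range from 800 nM to 30000 nM, and with a real chance that only a limit is returned.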

Compound 4, inhibition constant: 4000 nM
Beside the measured number, compound 4's estimate is 1.3-fold (0.10 log units) above it; the measured number falls inside the stated range.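

In this assay, propylamino in place of cyclopropyl on a carbonyl carbon gives a 1.0-fold lower number from compound 1 to compound 4 (0.01 log units; within the scatter), the first step the series can offer. On this carbonyl carbon, the two groups therefore cannot be told apart, and the series now has a second number in the same region rather than a single anchor. The step from compound 3 and any step involving compound 2 cannot be read, so the ethyl change itself remains unsized, and nothing available bears on the result.

Open is whether the chain on the amide-type nitrogen matters at all: methylamino has no number, and a longer chain such as hexylamino is not among the compounds shown. Also open, on these data alone, is whether a benzylamino group or a carboxylic acid at this carbonyl carbon would leave the number in this region.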